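Swapping the aryl group on a six-carbon ether linker

The compounds below may be only part of what the source reports. "The series", "measured", "known", "first", "only" and "open" are said of these compounds alone.

Three compounds were measured in an ADME assay on BHK cells (Mesocricetus auratus) for cytotoxicity, read by MTT assay; a lower number here means that less compound is tolerated, a higher number that more compound is tolerated:
compound 1, `CC1CCC(OCCCCCCN2C[C@H](O)[C@@H](O)[C@H](O)[C@H]2CO)CC1C`, only a limit, > 500000 nM;
compound 2, `CCC1CCC(OCCCCCCN2C[C@H](O)[C@@H](O)[C@H](O)[C@H]2CO)CC1`, 475000 nM;
compound 3, `COc1ccccc1OCCCCCCN1C[C@H](O)[C@@H](O)[C@H](O)[C@H]1CO`, only a limit, > 500000 nM.

Compound 3 thus stands at the limit of > 500000 nM in this assay, at which 2 of the 3 values shown sit, and its value is a limit rather than a number. The measured steps are small: an at least 1.0-fold lower number from compound 1 to compound 2 (0.02 log units; that floor lies within the scatter), an at least 1.0-fold higher number from compound 2 to compound 3 (0.02 log units; that floor lies within the scatter), while a step that the two limits leave unreadable from compound 1 to compound 3. Compound 4, `OC[C@@H]1[C@@H](O)[C@H](O)[C@@H](O)CN1CCCCCCOc1cc(F)ccc1F`, differs from compound 3 by 2,5-difluorophenyl in place of 2-methoxyphenyl on an oxygen on a saturated carbon. Since the replacements already seen on this oxygen moved the readout by nothing beyond the scatter, no step beyond the scatter is expected here either. Compound 4 is therefore estimated at 500000 nM, within 250000 nM to 1000000 nM. This estimate means an expected a number no higher from compound 3 to compound 4 (the limit leaves the size open).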

Compound 4, half-maximal cytotoxic concentration in the BHK assay: > 500000 nM
Compound 4: only a limit was reported (the forecaster's own chance of this, stated with the estimate: 60%); the middle value sits exactly at the limit.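

In the BHK assay the fluorinated aryl group gives an at least 1.0-fold higher number from compound 2 to compound 4 (0.02 log units; that floor lies within the scatter), while the steps to compound 4 from compound 1 and from compound 3 cannot be read, as both ends are limits. The 2,5-difluorophenyl group thus joins the other groups on this oxygen in reaching the same limit: the limit of > 500000 nM in the BHK assay, at which 3 of the 4 values shown sit.

In a physicochemical assay for solubility, in phosphate buffer, at pH 7.4 (on this read-out higher numbers stand for higher solubility and lower numbers for lower solubility), compound 3 gives 293000 nM and compound 4 gives 292000 nM, which is a 1.0-fold lower number from compound 3 to compound 4 (0.00 log units; within the scatter).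

From the compounds shown here alone, whether a carboxylic acid in place of these groups on this oxygen, or a longer chain, would give a measurable number in the BHK assay stays open.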